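This account rests on a few compounds, and the source may have more. Where it says the series, first, only, none or still open, it means among the compounds named here.

Measured compounds in a functional assay on HeLa S3 cells (Homo sapiens) for antiproliferative activity, read by XTT assay, with a stated time of 72 h; on this read-out lower numbers stand for stronger inhibition and higher numbers for weaker inhibition:
- compound 1 `CN(C)c1ncnc2c1c(-c1ccoc1)cn2[C@@H]1O[C@H](CO)[C@@H](O)[C@H]1O` gives 9060 nM.
- compound 2 `Cc1ncnc2c1c(-c1cccs1)cn2[C@@H]1O[C@H](CO)[C@@H](O)[C@H]1O` gives only a limit of the assay, > 15000 nM.
- compound 3 `CNc1ncnc2c1c(-c1cccs1)cn2[C@@H]1O[C@H](CO)[C@@H](O)[C@H]1O` gives only a limit of the assay, > 20000 nM.

Compound 3 therefore stands at a limit, not at a number; among the three values shown, its limit is the higher of the two limits recorded, and only compound 1 has a measured number. The step that the two limits leave unreadable from compound 2 to compound 3 cannot be read, since both ends are limits.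

Compound 4 `CN(C)c1ncnc2c1c(-c1cccs1)cn2[C@@H]1O[C@H](CO)[C@@H](O)[C@H]1O` differs from compound 3 by methyl in place of hydrogen on a nitrogen on an aromatic ring. No measured step bears directly on this change, and no shown evidence gives a cause for any step here. Compound 1, which carries the same dimethylamino group, gives 9060 nM. On that footing, compound 4 is expected to show weak inhibition, with a step of about an at least 1.3-fold lower number from compound 3 to compound 4 (0.12 log units; that floor lies within the scatter) that cannot be placed beyond the scatter, and an estimated value of 15000 nM with a range from 6000 nM to 40000 nM.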

Compound 4, half-maximal inhibitory concentration: > 20000 nM
Compound 4 ended at the assay's limit (the forecaster's own chance of this, stated with the estimate: 40%); at least 1.3-fold (0.12 log units) between middle value and limit.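

In this assay compound 4 gives only a limit of the assay, > 20000 nM. Adding the methyl on the nitrogen of compound 3 therefore yields no measured number, and no step among compound 2, compound 3 and compound 4 can be read, since each has limits at both ends: the limit of > 20000 nM in this assay, at which 2 of the 4 values shown sit. With dimethylamino kept, thiophen-2-yl in place of furan-3-yl gives an at least 2.2-fold higher number from compound 1 to compound 4 (0.34 log units; beyond the scatter), the one readable step here.

From the compounds shown here alone, how far compound 3 and compound 4 lie past their limits stays open. Going by these compounds, whether a phenyl group on that aromatic carbon, or a plain amino group in place of dimethylamino, would give a measured number also stays open.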